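The compounds below may be only part of what the source reports. "The series", "measured", "known", "first", "only" and "open" are said of these compounds alone.

Of the compounds shown here, three that share one core have been measured in a functional assay on DU-145 cells (Homo sapiens) for cytotoxicity, read by CCK-8 assay and cell counting, with a stated time of 2 days; a lower number here means a stronger inhibitor, a higher number a weaker inhibitor. Compound 1 `Oc1ccc(-c2cc(-c3ccccc3)nc(-c3ccccc3Cl)c2)cc1` gives 2800 nM, the lowest of the three numbers. Compound 2 `Oc1cccc(-c2cc(-c3ccc(Cl)cc3)nc(-c3ccccn3)c2)c1` gives 8090 nM in this assay, and compound 3 `Oc1ccc(-c2cc(-c3cccnc3)nc(-c3cccc(Cl)c3)c2)cc1` gives 22900 nM. Both of those numbers lie beyond the usual scatter from the number of compound 1, so compound 1 stands as the most potent of the three. No two of these compounds differ from each other in only one place, so the spread of numbers cannot be pinned to any single change in structure.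

Compound 4 `Oc1ccc(-c2cc(-c3ccsc3)nc(-c3ccccc3Cl)c2)cc1` has not yet been measured. It differs from compound 1 in exactly one place: thiophen-3-yl in place of phenyl on an aromatic carbon. Among the measured compounds nothing isolates this kind of exchange, so there is no measured step to lean on. An exchange of one aromatic ring for another of similar size is, in general, a modest change, and the step from compound 1 to compound 4 is expected to stay within the scatter, a 1.1-fold higher number from compound 1 to compound 4 (0.03 log units; within the scatter). Compound 4 is therefore estimated at 3000 nM in this assay, with a range from 1200 nM to 7500 nM.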

Compound 4, half-maximal inhibitory concentration: 3890 nM
For compound 4 the middle estimate is 1.3-fold (0.11 log units) below the measured one, and the stated range covers the measured number.
By their numbers in this assay, from the lowest: compounds 1 and 4 (each within the scatter of the next); then compound 2; then compound 3.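

Among the compounds shown here, this is the first pair that differs in one place only, so a single change can be read on its own in this assay: putting thiophen-3-yl in place of phenyl, on the aromatic carbon next to the ring nitrogen, amounts to a 1.4-fold higher number from compound 1 to compound 4 (0.14 log units; within the scatter) and so stays within the usual scatter of repeated measurements. At this position, then, a six-membered aromatic ring of carbon only and a five-membered aromatic ring holding a sulfur atom cannot be told apart in this pair, although the sulfur also brings a hydrogen-bond acceptor that phenyl lacks by the computed count. No separate measurement bears on this result, so it stands as an observation with no explanation attached.

Still open, as far as these compounds go, is whether this position accepts only aromatic rings or would also take a quite different group, such as a saturated cyclohexyl ring, an amine or a carboxylic acid. Also open, from the compounds shown here alone, is whether the same exchange would read alike if the 2-chlorophenyl group or the 4-hydroxyphenyl group were replaced at the same time.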